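Methoxy for bromo on the sulfonyl aryl of compound 1

The source may report more compounds than this note shows. Statements on the series, on what has been measured and on what is new or still open speak of the compounds shown alone.

Compound 1 `O=S(=O)(NCCCNc1nccc(-c2c(-c3cccc(F)c3)nc3sccn23)n1)c1ccc(Br)cc1` sits at the weak end of the two measured compounds: in a functional assay on A-375 cells (Homo sapiens) for cytotoxicity, read by MTT assay (a lower number here means a stronger inhibitor, a higher number a weaker inhibitor), compound 1 gives 7040 nM, the higher of the two numbers. Compound 2 `O=C(NCCNc1nccc(-c2c(-c3cccc(F)c3)nc3sccn23)n1)c1c(F)cccc1F` gives 2700 nM in this assay. Going by the values given here, the single measured step, a 2.6-fold lower number from compound 1 to compound 2 (0.42 log units; beyond the scatter), replaces the whole (4-bromophenyl)sulfonyl amino arm and its chain with a (2,6-difluorophenyl)carbonyl amino group on a different chain, so it changes two parts of the molecule at once.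

Compound 3 `COc1ccc(S(=O)(=O)NCCCNc2nccc(-c3c(-c4cccc(F)c4)nc4sccn34)n2)cc1` keeps the chain and the sulfonyl amino link of compound 1 and differs from it only by methoxy in place of bromo on an aromatic carbon. Among the compounds with values here, no measured step touches this aryl substituent on its own: the one step known alters linker and aryl together and cannot be read as a change of the substituent alone. With nothing bearing on it, no step beyond the scatter is expected in this assay, in either direction. Compound 3 is therefore estimated at 7000 nM, with a range from 3000 nM to 16000 nM. The expected step (a 1.0-fold lower number from compound 1 to compound 3 (0.00 log units; within the scatter)) stays within the scatter.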

Compound 3, half-maximal inhibitory concentration: 5510 nM
For compound 3 the middle estimate is 1.3-fold (0.10 log units) above the measured one; the range from low to high includes it.
By their numbers in this assay, from the lowest: compound 2; then compounds 3 and 1 (each within the scatter of the next).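

Read alone, methoxy in place of bromo on the sulfonyl aryl gives a 1.3-fold lower number from compound 1 to compound 3 (0.11 log units; within the scatter) in this assay, the first reading of this position without a change of chain or link. The hydrogen-bond acceptor that enters with methoxy, where bromo brings none, therefore comes with no step beyond the scatter, so this pair gives the aromatic carbon no measurable weight in this cytotoxicity read-out, for these two groups only. No available measurement bears on why bromo and methoxy read alike here.

The comparison of the sulfonyl compounds with compound 2 still changes chain and aryl arm together, so the lower number of compound 2 cannot yet be assigned to the (2,6-difluorophenyl)carbonyl group, to the carbonyl amino link or to the chain. Also open, as far as these compounds go, is whether a more different group on the same aromatic carbon, such as an amine or a carboxylic acid, would give a step beyond the scatter, and whether a longer chain would do so with the 4-methoxyphenyl sulfonyl arm kept in place.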